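The source may report more compounds than this note shows. Statements on the series, on what has been measured and on what is new or still open speak of the compounds shown alone.

compound 1 `Cc1c2c(n3c1CCCN[C@@H](C)[C@H](C)Nc1cc-3ccc1C(N)=O)CC(C)(C)CC2=O`: 20 nM
compound 2 `Cc1c2c(n3c1CCN(C)C[C@@H](C)[C@H](C)Nc1cc-3ccc1C(N)=O)CC(C)(C)CC2=O`: 27 nM
compound 3 `CC(=O)N1CCc2c(C)c3c(n2-c2ccc(C(N)=O)c(c2)N[C@@H](C)[C@H](C)C1)CC(C)(C)CC3=O`: 15 nM

In a functional assay on NCI-H1975 cells (Homo sapiens) for antiproliferative activity (on this read-out higher numbers stand for weaker inhibition and lower numbers for stronger inhibition), the value of compound 1 lies within the scatter of the values of both compound 2 and compound 3, so the three are not separated. Compound 4 `Cc1c2c(n3c1CCCN(C(=O)CN)[C@@H](C)[C@H](C)Nc1cc-3ccc1C(N)=O)CC(C)(C)CC2=O` is compound 1 with (aminomethyl)carbonyl in place of hydrogen on an amine nitrogen in a ring. The closest measured change is a 1.8-fold lower number from compound 2 to compound 3 (0.26 log units; within the scatter), with acetyl in place of methyl on an amine nitrogen in a ring. Among the measured compounds shown here, no measured step starts from hydrogen at such a nitrogen, so the basis is thin, and the range is kept wide. No shift beyond the scatter is expected in this assay, in either direction. The expected step is a 1.3-fold higher number from compound 1 to compound 4 (0.10 log units; within the scatter). Compound 4 is estimated at 25 nM, with an expected range of 8 nM to 80 nM.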

Compound 4, half-maximal inhibitory concentration: 380 nM
Beside the measured number, compound 4's estimate is 15-fold (1.18 log units) below it, outside the stated range (above it).
By their numbers in this assay, from the lowest: compounds 3, 1 and 2 (each within the scatter of the next); then compound 4.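

In this assay, the amine nitrogen in the ring of compound 1 is not indifferent to substitution: (aminomethyl)carbonyl in place of hydrogen gives a 19-fold higher number from compound 1 to compound 4 (1.28 log units; beyond the scatter). Among the earlier compounds, the only step at a ring amine nitrogen stayed within the scatter, so this is the first large step in the series.

The compounds shown do not tell whether the step follows the carbonyl or the terminal amine, which a hydroxyacetyl group or a longer aminoacyl chain on this nitrogen could separate. Nothing available gives a reason for the step.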